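This account rests on a few compounds, and the source may have more. Where it says the series, first, only, none or still open, it means among the compounds named here.

Compound 1, with the structure `O=C1C(=O)N(CN2CCN(c3ccnc4cc(C(F)(F)F)ccc34)CC2)c2cccc(Cl)c21`, and compound 2, with the structure `O=C1C(=O)N(CN2CCN(c3ccnc4cc(C(F)(F)F)ccc34)CC2)c2cccc(Br)c21`, share one core and differ only at a single halogen. In an ADME assay on MCF-10A cells (Homo sapiens) for cytotoxicity, read by sulforhodamine B assay, with a stated time of 48 h (on this read-out higher numbers stand for weaker inhibition of growth and lower numbers for stronger inhibition of growth), compound 1 gives 24000 nM. Compound 2 gives 37900 nM in this assay. The change between them is bromo in place of chloro on an aromatic carbon, and it made a step of a 1.6-fold higher number from compound 1 to compound 2 (0.20 log units; within the scatter), a move that stays inside the ordinary spread of repeated measurements, so the two compounds cannot be told apart on this read-out.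

Compound 3, with the structure `NC(=S)N/N=C1/C(=O)N(CN2CCN(c3ccnc4cc(Cl)ccc34)CC2)c2cccc(Cl)c21`, carries a different core, and the difference between the two cores is not broken down here. In this assay compound 3 gives 19800 nM, a number that sits within the scatter of both compound 1 and compound 2.

Compound 4, with the structure `NC(=S)N/N=C1/C(=O)N(CN2CCN(c3ccnc4cc(Cl)ccc34)CC2)c2cccc(Br)c21`, has not yet been tested. It stands to compound 3 as compound 2 stands to compound 1: the change is bromo in place of chloro on an aromatic carbon, at a position described in the same words for both pairs, so it is the same change on another core. Within the data shown here, the expectation for the step from compound 3 to compound 4 is a 1.3-fold higher number from compound 3 to compound 4 (0.12 log units; within the scatter), set beside the earlier step because the only evidence for this swap is the step of a 1.6-fold higher number from compound 1 to compound 2 (0.20 log units; within the scatter), which was small. On that basis the estimate for compound 4 is 26000 nM, with a likely range from 13000 nM to 52000 nM.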

Compound 4, concentration for 50% growth inhibition: 29400 nM
Compound 4: the middle estimate sits 1.1-fold (0.05 log units) below what was measured; low and high end bracket the measured number.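

In this assay, putting bromo in place of chloro on an aromatic carbon gave a 1.5-fold higher number from compound 3 to compound 4 (0.17 log units; within the scatter), and this step can be set beside the same swap on the other core: the same change on two cores in this assay, a 1.6-fold higher number (0.20 log units; within the scatter) from compound 1 to compound 2 and a 1.5-fold higher number (0.17 log units; within the scatter) from compound 3 to compound 4, 1.1-fold (0.03 log units) apart, within the scatter of two such steps. So, in these two pairs, the swap looks the same on both cores, and the step seen on one core was a fair guide to the step on the other. This does not show that bromo and chloro truly differ in this series, since each step lies within the scatter, and two pairs that agree on a small step are too few to establish a rule for other cores.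

The compounds shown carry only chloro or bromo at this place on the ring, so it remains open what an amine, a methoxy group or a longer carbon chain would do there in this assay. From the compounds shown here alone, it also remains open whether a swap at this place could give a step beyond the scatter, and whether such a step would carry from one core to the other as this small one does.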